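A few compounds are considered here, and "the series" means these few. Any claim that something is new, unique, unknown or untested is made for them only; others in the source may bear on it.

In a functional assay on B16 cells (Mus musculus) for antiproliferative activity, read by MTT assay, with a stated time of 24 h (a higher number here means a weaker inhibitor, a lower number a stronger inhibitor), compound 1 `COc1cc(OC)c(-c2coc3cc(OCc4ccccc4)ccc3c2=O)cc1OC` gives 2330 nM and compound 3 `COc1cc(OC)c(-c2coc3cc(OCc4ccccc4C#N)ccc3c2=O)cc1OC` gives 2140 nM. These two stand level, as the step of a 1.1-fold lower number from compound 1 to compound 3 (0.04 log units; within the scatter) shows. Compound 2 `COc1cc(OC)c(-c2coc3cc(OCC(=O)c4cccc(C(F)(F)F)c4)ccc3c2=O)cc1OC` reads > 10000 nM, which is a limit of the assay. Compound 4 `COc1cc(OC)c(-c2coc3cc(OCc4cccc(Br)c4)ccc3c2=O)cc1OC` carries 3-bromophenyl in place of 2-cyanophenyl on a saturated chain carbon bound to an oxygen on an aromatic ring. The steps of an at least 4.2-fold higher number from compound 1 to compound 2 (0.63 log units; beyond the scatter) and an at least 4.6-fold lower number from compound 2 to compound 3 (0.66 log units; beyond the scatter) go beyond the scatter, but both involve the carbonyl of compound 2, which compound 4 lacks. The nearer guide is a 1.1-fold lower number from compound 1 to compound 3 (0.04 log units; within the scatter), a change on the phenyl ring alone. No step beyond the scatter is therefore expected in this assay, the estimate being a 1.2-fold higher number from compound 3 to compound 4 (0.07 log units; within the scatter). For compound 4 the estimated value is 2500 nM, with a range of 1000 nM to 6500 nM.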

Compound 4, half-maximal inhibitory concentration: 4400 nM
Compound 4: the middle estimate sits 1.8-fold (0.25 log units) below what was measured; measured number inside the range.
By their numbers in this assay, from the lowest: compounds 3, 1 and 4 (each within the scatter of the next, the first and the last beyond it). At a limit, above all of these: compound 2.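

In this assay, the ring on this saturated chain carbon shows its first step beyond the scatter among compounds without the carbonyl: a 2.1-fold higher number from compound 3 to compound 4 (0.31 log units; beyond the scatter), though a modest one. Bromo in place of hydrogen alone gives a 1.9-fold higher number from compound 1 to compound 4 (0.28 log units; within the scatter), so neither substituent separates clearly from the unsubstituted compound 1. The step of an at least 2.2-fold lower number from compound 2 to compound 4 (0.35 log units; beyond the scatter) starts from a limit, not a number: the limit of > 10000 nM in this assay, at which 1 of the 4 values shown sits.

Going from 2-cyanophenyl to 3-bromophenyl changes both the group and where it sits, and the compounds shown cannot separate the two. On these data alone, how an amine or a carboxylic acid on this ring would read remains open.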